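The source may hold more compounds than are shown below. What is called first, only, known or untested is meant among the compounds shown, and "the series" means these compounds.

Measured so far in a functional assay on HCT-116 cells (Homo sapiens) for antiproliferative activity, read by MTT assay, with a stated time of 48 h; a lower number here means a stronger inhibitor, a higher number a weaker inhibitor (values below)
- compound 1 `Cc1ccc(NC(=O)c2oc3ccc(N(Cc4ccc(Br)cc4)S(=O)(=O)c4ccc(Br)cc4)cc3c2C)nc1`: > 40000 nM (a limit of the assay, not a number)
- compound 2 `CN(C)CCNC(=O)c1nc2cc(N(Cc3ccc(Br)cc3)S(=O)(=O)c3ccc(Br)cc3)ccc2o1`: 14300 nM

For the measured compounds named here, compound 2 at 14300 nM holds the only true number in this assay so far. Compound 3 `CN1CCC(NC(=O)c2nc3cc(N(Cc4ccc(Br)cc4)S(=O)(=O)c4ccc(Br)cc4)ccc3o2)CC1` has 1-methylpiperidin-4-yl in place of 2-(dimethylamino)ethyl on an amide-type nitrogen and is still unmeasured. Going by the values given here, no measured step covers this change, so no shift beyond the scatter is expected, in either direction. The estimated step is a 1.3-fold lower number from compound 2 to compound 3 (0.11 log units; within the scatter) and remains within that scatter. Compound 3 is expected at 11000 nM in this assay with an estimated range of 4000 nM to 30000 nM for the coming measurement.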

Compound 3, half-maximal inhibitory concentration: 7320 nM
Estimate against measurement, compound 3: 1.5-fold (0.18 log units) above; low and high end bracket the measured number.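

In this assay, 1-methylpiperidin-4-yl in place of 2-(dimethylamino)ethyl on the amide-type nitrogen gives a 2.0-fold lower number from compound 2 to compound 3 (0.29 log units; within the scatter). For the compounds shown here, this is the first step read at this position, and it shows that the open chain can give way to a six-membered non-aromatic ring without a shift beyond the scatter. No available evidence bears on this step.

Going by these compounds, a morpholine ring, a longer aminoalkyl chain or a plain alkyl group without an amine on this nitrogen remains open. A single pair sets no trend for the position.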